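Chain extension in a series that reaches only the assay limit

The source may report more compounds than this note shows. Statements on the series, on what has been measured and on what is new or still open speak of the compounds shown alone.

Compound 1 `CCCCN(C)C(=O)CCCOc1cc(OC)c(OC)c2oc(-c3ccc(OC)cc3)c(O)c(=O)c12` carries a butyl(methyl)carbamoyl group on the chain that hangs from the shared core. In a functional assay on A549 cells (Homo sapiens) for antiproliferative activity, read by sulforhodamine B assay, with a stated time of 48 h (on this read-out lower numbers stand for stronger inhibition and higher numbers for weaker inhibition), compound 1 gives only a limit, > 40000 nM. Compound 2 `COc1ccc(-c2oc3c(OC)c(OC)cc(OCCCC(=O)N4CCN(C)CC4)c3c(=O)c2O)cc1` also reaches only a limit in this assay, > 40000 nM. Compound 3 `COc1ccc(-c2oc3c(OC)c(OC)cc(OCCCCC(=O)N4CCN(C)CC4)c3c(=O)c2O)cc1` likewise yields a limit, > 40000 nM. The steps a step that the two limits leave unreadable from compound 1 to compound 2 and a step that the two limits leave unreadable from compound 1 to compound 3 are therefore unreadable, and the limit of > 40000 nM in this assay, at which 3 of the 3 values shown sit, leaves compound 1 without a numerical standing. Compound 4 `CCCCCN(C)C(=O)CCCCCOc1cc(OC)c(OC)c2oc(-c3ccc(OC)cc3)c(O)c(=O)c12` differs from compound 1 by 2-(methyl(pentyl)carbamoyl)ethyl in place of butyl(methyl)carbamoyl on a saturated chain carbon, three bonds along the chain from an oxygen on an aromatic ring. For the measured compounds named here, no measured step reads a direction for such a change, so no step beyond the scatter is expected, and another limit is the likely outcome. For compound 4 the estimate is 60000 nM, spanning 20000 nM to 200000 nM, an expected step that the limit leaves unreadable from compound 1 to compound 4.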

Compound 4, half-maximal inhibitory concentration: 17200 nM
Estimate against measurement, compound 4: 3.5-fold (0.54 log units) above; measured number below the stated range.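

For the compounds shown here, compound 4 gives the only number in this assay, so steps on this saturated chain carbon can be read for the first time, where all earlier ones could not: the limit of > 40000 nM in this assay, at which 3 of the 4 values shown sit. The change to 2-(methyl(pentyl)carbamoyl)ethyl gives an at least 2.3-fold lower number from compound 1 to compound 4 (0.36 log units; beyond the scatter). Measured from the 4-methylpiperazin-1-yl amides, the change gives an at least 2.3-fold lower number from compound 2 to compound 4 (0.36 log units; beyond the scatter) and an at least 2.3-fold lower number from compound 3 to compound 4 (0.36 log units; beyond the scatter), and each of these three steps is only a bound, with chain and amide group changing together. The compounds shown leave open whether a longer chain ending in butyl(methyl)carbamoyl, or a carboxylic acid in place of the amide, would give a lower number.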